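Solubility on the triazole substituent: sugar versus carboxymethyl

A few compounds are considered here, and "the series" means these few. Any claim that something is new, unique, unknown or untested is made for them only; others in the source may bear on it.

Compound 2 `CC(C)(C)c1[nH]cnc1/C=c1\[nH]c(=O)/c(=C/c2ccccc2)nc1OCOC(=O)CCCc1cn([C@@H]2O[C@H](CO)[C@H](O)[C@H](O)[C@H]2O)nn1` gives 7.5 ug/mL in a physicochemical assay for solubility, read by HPLC, with a stated time of 15 min (on this read-out lower numbers stand for lower solubility and higher numbers for higher solubility), the lowest of the two numbers in hand; its nearest neighbour is compound 1 `CC(C)(C)c1[nH]cnc1/C=c1\[nH]c(=O)/c(=C/c2ccccc2)nc1OCOC(=O)CCCc1cn(C[C@H](O)CC(=O)O)nn1` with 850 ug/mL. Compound 3 `CC(C)(C)c1[nH]cnc1/C=c1\[nH]c(=O)/c(=C/c2ccccc2)nc1OCOC(=O)CCCc1cn(CC(=O)O)nn1` differs from compound 2 by carboxymethyl in place of 3,4,5-trihydroxy-6-(hydroxymethyl)oxan-2-yl on an aromatic nitrogen. Going by the values given here, the one measured step that bears on this is a 110-fold lower number from compound 1 to compound 2 (2.05 log units; beyond the scatter), where an acid-bearing chain on the same aromatic nitrogen was swapped for the sugar. Compound 3 takes the sugar off again, so a large rise in this assay is expected, a 67-fold higher number from compound 2 to compound 3 (1.82 log units; beyond the scatter). Compound 3 is therefore estimated at 500 ug/mL, with a range of 150 ug/mL to 1500 ug/mL.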

Compound 3, solubility: 590 ug/mL
Compound 3: the middle estimate sits 1.2-fold (0.07 log units) below what was measured, within the range that was stated.
By their numbers in this assay, from the lowest: compound 2; then compounds 3 and 1 (each within the scatter of the next).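

On this aromatic nitrogen, carboxymethyl in place of 3,4,5-trihydroxy-6-(hydroxymethyl)oxan-2-yl gives, in this assay, a 79-fold higher number from compound 2 to compound 3 (1.90 log units; beyond the scatter), so compound 2 now stands apart from two chains that carry a carboxylic acid, not just one. Between those two chains the change is a 1.4-fold lower number from compound 1 to compound 3 (0.16 log units; within the scatter), so the chain length and hydroxy group that separate them show no readable effect on this read-out. No measurement shown accounts for either step. As far as these compounds go, whether an amine or a hydroxyethyl chain on this nitrogen would fall with compound 2 or with compounds 1 and 3 remains open.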